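The source may report more compounds than this note shows. Statements on the series, on what has been measured and on what is new or still open speak of the compounds shown alone.

Working notes on a small set of acylguanidine-type compounds examined in a functional assay on HEK293T cells for agonist activity at histamine H2 receptor (Homo sapiens), read by beta-arrestin recruitment; on this read-out higher numbers stand for larger maximal responses and lower numbers for smaller maximal responses.

Three compounds carry the same aminothiazole-bearing core, the structures being compound 1 `N/C(=N\C(=O)NC1CCCCC1)Nc1cccc(-c2csc(N)n2)c1`, compound 2 `CCCNC(=O)/N=C(\N)Nc1cccc(-c2csc(N)n2)c1` and compound 3 `Cc1nc(N)sc1CCCN/C(N)=N/C(=O)NC1CCCCC1`. For compound 1 the entry in this assay reads "not determined" (no result reported), and for compound 2 it likewise reads "not determined" (no result reported), so neither contributes a number. Among the compounds with values here, compound 3 is therefore the only member with a value: in this assay compound 3 gives 0.43, a partial response relative to the reference agonist. Within the data shown here, with no second number there is no measured step to lean on, and no pattern can be claimed across compound 1, compound 2 and compound 3.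

Compound 4 `CCCCCNC(=O)/N=C(\N)NCCCc1sc(N)nc1C` is not yet measured. It differs from compound 3 at a single place: pentyl in place of cyclohexyl on an amide-type nitrogen. Pentyl in place of cyclohexyl on the amide-type nitrogen is a modest change in the size of the group and leaves the rest of the molecule untouched.

The step from compound 3 to compound 4 is expected to be small, of about a number 0.020 higher from compound 3 to compound 4 (within the scatter), and not clearly beyond the usual scatter in either direction. On that basis compound 4 is estimated to reach 0.45 in this assay, within a range of 0.25 to 0.65.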

Compound 4, intrinsic activity: the largest response reached, as a fraction of the reference agonist's: 0.15
The estimate for compound 4 lay 0.30 above the measured number; the whole stated range lies above it.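

In this assay, within the data shown here, pentyl in place of cyclohexyl on the amide-type nitrogen gives a number 0.28 lower from compound 3 to compound 4 (beyond the scatter), the first measured step, so the maximal response is sensitive to the group at this position. Cyclohexyl and pentyl are both carbon-only groups with no hydrogen-bond donors or acceptors and no net charge, and the visible structural difference is that the ring of cyclohexyl gives way to the open chain of pentyl. This remains a description of the change and not an explanation, as nothing in hand accounts for the size of the step.

A hexyl chain, a cyclopentyl ring or a phenyl ring on the same nitrogen would help separate the loss of the ring from the length and size of the group, and the present pair cannot distinguish these. Steps involving compound 1 and compound 2 cannot be read, so whether the cyclohexyl and alkyl groups compare in the same way on the core of those compounds remains open.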